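Thiophene Variation: Cytotoxicity Notes on Compounds 2 and 3

The source may hold more compounds than are shown below. What is called first, only, known or untested is meant among the compounds shown, and "the series" means these compounds.

Measured so far:
compound 1 `O=C(/C=C/c1ccc(N2CCCCC2)cc1)c1ccsc1`: > 100000 nM
compound 2 `Cc1ccsc1C1=NNC(c2ccc(N3CCCCC3)cc2)C1`: 11000 nM

In an ADME assay on PBMC cells (Homo sapiens) for cytotoxicity, with a stated time of 5 days (a lower number here means a stronger inhibitor, a higher number a weaker inhibitor), compound 1 gives > 100000 nM, which is a limit of the assay and not a number. Compound 2 gives 11000 nM in this assay. That is the only number shown; the other value sits at the limit of > 100000 nM in this assay, at which 1 of the 2 values shown sits.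

Compound 3 `Cc1cc(C2=NNC(c3ccc(N4CCCCC4)cc3)C2)c(C)s1` differs from compound 2 by 2,5-dimethylthiophen-3-yl in place of 3-methylthiophen-2-yl on a carbon with a double bond to nitrogen. For the measured compounds named here, no measured step covers this change, so the expectation is a step in this assay that stays within the scatter, with no clear direction. Compound 3 is expected to give about 15000 nM in this assay, between 5000 nM and 50000 nM. The expected step is a 1.4-fold higher number from compound 2 to compound 3 (0.13 log units; within the scatter).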

Compound 3, half-maximal inhibitory concentration: 77500 nM
For compound 3 the middle estimate is 5.2-fold (0.71 log units) below the measured one; measured number above the stated range.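

In this assay, 2,5-dimethylthiophen-3-yl in place of 3-methylthiophen-2-yl gives a 7.0-fold higher number from compound 2 to compound 3 (0.85 log units; beyond the scatter), so the thiophene on this carbon with a double bond to nitrogen does register in the read-out. The methyl pattern and the thiophene attachment both differ in this change, so the step cannot be assigned to either one alone. Nothing on hand accounts for the size of the step.

Still open, as far as these compounds go, is how an unsubstituted phenyl ring or a thiophene carrying an amine would read at this position.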